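A few compounds are considered here, and "the series" means these few. Any claim that something is new, unique, unknown or untested is made for them only; others in the source may bear on it.

Measured so far:
- compound 1 `Fc1cc(I)ccc1Nc1nc2nonc2nc1Nc1ccc(I)cc1F`: 8800 nM
- compound 2 `Fc1cccc(Nc2nc3nonc3nc2Nc2ccccc2F)c1`: 190 nM

In an assay on mitochondria from L6 cells (Rattus norvegicus) for activation, with a stated time of 90 min (a higher number here means that more compound is needed for the effect, a lower number that less compound is needed), compound 2 gives 190 nM, the lowest of the two numbers recorded; compound 1 gives 8800 nM, a gap that lies beyond the scatter. Within the data shown here, no pair of measured compounds differs in a single place, so there is no measured step to lean on for the change that follows.

Compound 3 `Cc1ccccc1Nc1nc2nonc2nc1Nc1ccccc1F` is not yet measured. It differs from compound 2 in one place: 2-methylphenyl in place of 3-fluorophenyl on a nitrogen on an aromatic ring. Among the measured compounds shown here, with no comparable step recorded, the size of this change in this assay is open; a modest step is expected, more likely toward a higher number than a lower one, and possibly none beyond the scatter. Compound 3 is therefore estimated at 400 nM, within a range of 100 nM to 1600 nM, which would correspond to an expected step of a 2.1-fold higher number from compound 2 to compound 3 (0.32 log units; beyond the scatter).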

Compound 3, half-maximal effective concentration: 1100 nM
Estimate against measurement, compound 3: 2.8-fold (0.44 log units) below, within the range that was stated.
By their numbers in this assay, from the lowest: compound 2; then compound 3; then compound 1.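

In this assay, the series now has its first comparison at a single place, (3-fluorophenyl)amino to (2-methylphenyl)amino, and it gives a 5.8-fold higher number from compound 2 to compound 3 (0.76 log units; beyond the scatter), so the group on this nitrogen matters in this assay. The two groups match in what is counted: each has 7 heavy atoms and one six-membered aromatic ring of carbon only, with 0 hydrogen-bond donors, 0 hydrogen-bond acceptors and no net charge, so these counts do not separate them. No measurement at hand bears on the reason for the step.

Open, from the compounds shown here alone, is whether the step follows the exchange of fluorine for methyl or the place of the group on the ring, which a 3-methylphenyl group on this nitrogen would help to separate. Compound 1 still has no single-place link to compound 2 or compound 3, so its high number cannot be assigned to any one change.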